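The source may hold more compounds than are shown below. What is called first, only, known or untested is meant among the compounds shown, and "the series" means these compounds.

For the measured compounds named here, compound 1 `CN(C)C(=O)CN1CCC(c2cc3c(-c4ccc(=O)n(C5CCC5)c4)ccnc3[nH]2)CC1` is one of two compounds measured in a physicochemical assay for lipophilicity, using the shake flask method, measured as octanol-water partition, at pH 7.4; on this read-out higher numbers stand for higher lipophilicity and lower numbers for lower lipophilicity; in this assay compound 1 gives 1.9. The other is compound 2 `CC(=O)N1CCC(c2cc3c(-c4ccc(=O)n(C(C)C)c4)ccnc3[nH]2)CC1`, which in this assay gives 2.1. The two numbers lie within the scatter of each other, so the data do not separate compound 1 from compound 2 in this assay; compound 1 simply holds the lower of the two numbers. Compound 3 `CC(C)Cn1cc(-c2ccnc3[nH]c(C4CCN(CC(=O)N(C)C)CC4)cc23)ccc1=O` has not yet been measured in this assay. It differs from compound 1 in one place: isobutyl in place of cyclobutyl on an aromatic nitrogen. Going by the values given here, no measured pair in this set shows such a change, so its effect in this assay is not known from these data. The expected step from compound 1 to compound 3 is small, upward at most, a number 0.20 log units higher from compound 1 to compound 3 (within the scatter), and may well lie within the scatter. Compound 3 is therefore estimated at 2.1 in this assay, with a range from 1.7 to 2.5.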

Compound 3, distribution coefficient: 2
Beside the measured number, compound 3's estimate is 0.10 log units above it; low and high end bracket the measured number.
By their numbers in this assay, from the lowest: compounds 1, 3 and 2 (each within the scatter of the next).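

Isobutyl in place of cyclobutyl on an aromatic nitrogen gives a number 0.10 log units higher from compound 1 to compound 3 (within the scatter) in this assay, the first step read at this position. For this one pair, the four-membered ring can go while the count of heavy atoms stays the same, and the two compounds are still not separated in this measurement. Nothing at hand offers an explanation for this result.

The compounds shown leave open what a longer chain, or a group that is not plain carbon such as an amine or a carboxylic acid, would do on this aromatic nitrogen. Going by these compounds, it also remains open whether the same exchange of cyclobutyl for isobutyl would stay as small with a different group elsewhere on the core of compound 1.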